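The source may hold more compounds than are shown below. What is called first, only, known or untested is meant among the compounds shown, and "the series" means these compounds.

Working notes on the series. Among the compounds with values here, in a functional assay on MGC-803 cells (Homo sapiens) for inhibition, read by MTT assay, with a stated time of 48 h (a higher number here means a weaker inhibitor, a lower number a stronger inhibitor), compound 1 (`C/C=C/C(=O)N(Cc1ccc(OC)c(OC)c1)c1cc(OC)c(OC)c(OC)c1`) gives 20100 nM, and compound 2 (`C/C=C/C(=O)N(Cc1ccc(OC)c(N)c1)c1cc(OC)c(OC)c(OC)c1`) gives 150 nM, the lower of the two numbers so far. The next change starts from compound 2 and leads to compound 3 (`C/C=C/C(=O)N(Cc1ccc(OC)c(C)c1)c1cc(OC)c(OC)c(OC)c1`), with methyl in place of amino on an aromatic carbon, ortho to a methoxy group: methyl in place of amino on an aromatic carbon.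

Within the data shown here, only one measured step bears on this change. That step, a 130-fold lower number from compound 1 to compound 2 (2.13 log units; beyond the scatter), is large and beyond the scatter, and it introduced the amino group on the same aromatic carbon. Among the measured compounds shown here, no methyl compound has been measured, so the size of the new step rests on that single comparison. Compound 3 loses the amino group, so a rise beyond the scatter is expected in this assay, probably smaller than or similar to a 130-fold lower number from compound 1 to compound 2 (2.13 log units; beyond the scatter), though the evidence is thin.

For compound 3, the estimated value is 3000 nM, with an expected range of 500 nM to 18000 nM. This estimate means an expected 20-fold higher number from compound 2 to compound 3 (1.30 log units; beyond the scatter).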

Compound 3, half-maximal inhibitory concentration: 14500 nM
For compound 3 the middle estimate is 4.8-fold (0.68 log units) below the measured one; low and high end bracket the measured number.
By their numbers in this assay, from the lowest: compound 2; then compounds 3 and 1 (each within the scatter of the next).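

In this assay the change from amino to methyl gives a 97-fold higher number from compound 2 to compound 3 (1.99 log units; beyond the scatter), so the potency seen with amino does not carry over to methyl, although the two groups have the same heavy-atom count; the step removes the hydrogen-bond donor and acceptor counted for amino. Methyl and methoxy on this aromatic carbon are not told apart, with a 1.4-fold lower number from compound 1 to compound 3 (0.14 log units; within the scatter), which leaves compound 2 as the only one of the three whose number stands beyond the scatter from both others. No measurement at hand explains why the amino compound stands apart from the other two.

The compounds shown leave open whether the effect needs a free amino group specifically or would also appear with another small group on the same carbon, such as hydroxyl, methylamino or acetamido. They also leave open whether the large difference between amino and methyl would hold if the methoxy group ortho to this carbon were replaced, for example by ethoxy or by hydrogen.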